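A few compounds are considered here, and "the series" means these few. Any claim that something is new, unique, unknown or untested is made for them only; others in the source may bear on it.

Measured in a functional assay on PBMC cells (Homo sapiens) for inhibition, read by HTRF, with stated times of 15 min and 24 h; on this read-out lower numbers stand for stronger inhibition and higher numbers for weaker inhibition:
Compound 1 `O=C(Nc1ccc2c(c1)B(O)OC2)c1ccccc1F`: > 10000 nM, a limit.
Compound 2 `Cc1ccccc1C(=O)Nc1ccc2c(c1)B(O)OC2`: > 100000 nM, a limit.
Compound 3 `O=C(Nc1ccc2c(c1)B(O)OC2)c1c(F)cccc1C(F)(F)F`: 180 nM.

Compound 1 stands only at a limit, > 10000 nM, and has no exact number. Compound 4 `O=C(Nc1ccc2c(c1)B(O)OC2)c1cccc(C(F)(F)F)c1F` differs from it by trifluoromethyl in place of hydrogen on an aromatic carbon, with trifluoromethyl in place of hydrogen on an aromatic carbon, ortho to a fluoro group. The closest measured step is an at least 55-fold lower number from compound 1 to compound 3 (1.74 log units; beyond the scatter), which is large. The step that the two limits leave unreadable from compound 1 to compound 2 is a different exchange and gives little guidance. In compound 4 the trifluoromethyl stands on another aromatic carbon than in compound 3, so a lower number is expected in this assay, though probably a smaller drop. For compound 4 the estimated value is 1500 nM, with an expected range from 200 nM to 10000 nM. This estimate means an expected step of an at least 6.6-fold lower number from compound 1 to compound 4 (0.82 log units; beyond the scatter).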

Compound 4, half-maximal inhibitory concentration: > 100000 nM
Compound 4 ended at the assay's limit; the forecaster's own chance of this, stated with the estimate: 20%; at least 66-fold (1.82 log units) between middle value and limit.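

No step can be read from compound 1 to compound 4, since both values are limits and not numbers. The compounds shown leave open whether trifluoromethyl at this place, ortho to a fluoro group, changes inhibition at all.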